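The source may report more compounds than this note shows. Statements on the series, on what has been measured and on what is new or still open speak of the compounds shown alone.

Measured so far, in a functional assay on HepG2 cells (Homo sapiens) for cytotoxicity, read by MTT assay, with a stated time of 96 h; a lower number here means that less compound is needed, a higher number that more compound is needed for the effect:

compound 1 `COc1ccc(-c2[nH]c3ccc(OC)cc3c2/C=C(\C#N)S(=O)(=O)c2ccccc2)cc1`: 6400 nM
compound 2 `CC(=O)/C(=C/c1c(-c2ccccc2)[nH]c2ccccc12)C(=O)c1ccccc1`: 79000 nM
compound 3 `CCOC(=O)/C(=C/c1c(-c2ccccc2)[nH]c2ccccc12)C(=O)c1ccc([N+](=O)[O-])cc1`: 28000 nM

Among these three numbers compound 3 holds the second highest. Its nearest neighbour is compound 2, whose number is higher by more than the usual scatter, and the furthest is compound 1, whose number is lower by clearly more than the scatter. Compound 3 therefore sits between the two, neither the lowest nor the highest on this small set.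

Compound 4 `CCOC(=O)/C(=C/c1c(-c2ccccc2)[nH]c2ccccc12)C(=O)c1ccccc1` differs from compound 3 in one place: hydrogen in place of nitro on an aromatic carbon. Among the measured compounds shown here, no measured pair shows the effect of exactly this change, so the expectation rests only on the three numbers in hand. A change in the outer part of the molecule, away from the shared core, is expected to move the number only modestly, if at all, and any movement is expected to be toward a somewhat higher number. The step from compound 3 to compound 4 is estimated at a 1.4-fold higher number from compound 3 to compound 4 (0.15 log units; within the scatter). Compound 4 is expected to give about 40000 nM in this assay, within a range from 12000 nM to 130000 nM.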

Compound 4, half-maximal effective concentration: 31000 nM
Estimate against measurement, compound 4: 1.3-fold (0.11 log units) above; the measured number falls inside the stated range.
By their numbers in this assay, from the lowest: compound 1; then compounds 3 and 4 (each within the scatter of the next); then compound 2.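

In this assay, among the compounds shown here, the change at this spot is the first one that can be read on its own: with hydrogen in place of nitro, on an aromatic carbon para to a large group, the result is a 1.1-fold higher number from compound 3 to compound 4 (0.04 log units; within the scatter) and so shows no real shift. For the compounds shown here, the other change, ethoxy in place of methyl on a carbonyl carbon, gives a 2.5-fold lower number from compound 2 to compound 4 (0.41 log units; beyond the scatter) and lies beyond the scatter, so of these two single changes only this one moves the number by more than repeat measurements would. Nothing available here explains either step.

On these data alone, what an amine or a carboxylic acid on that aromatic carbon would do remains open. So does the effect of a longer chain in place of ethoxy on the carbonyl carbon.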